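This account rests on a few compounds, and the source may have more. Where it says the series, first, only, none or still open, it means among the compounds named here.

In an ADME assay on MRC5 cells (Homo sapiens) for cytotoxicity, read by fluorescence and resazurin assay, with a stated time of 24 h (a higher number here means a weaker inhibitor, a lower number a stronger inhibitor), compound 1 (`CCOC(=O)c1c(C(C)C)oc2nc(N3CCCC3)ccc12`) gives > 330000 nM, which is a limit of the assay and not a number. Compound 2 (`CCCSc1ccc2c(C(=O)OCC)c(C(C)C)oc2n1`) stands at "not determined" (no result reported), so it offers no number to start from. Compound 3 (`CCCCNc1ccc2c(C(=O)OCC)c(C(C)C)oc2n1`) is the next structure. The change is butylamino in place of propylsulfanyl on an aromatic carbon, on an aromatic carbon next to the ring nitrogen. For the measured compounds named here, the only guide is the limit of > 330000 nM in this assay, at which 1 of the 2 values shown sits, so compound 3 is expected to remain a weak inhibitor, with only a modest step toward stronger inhibition. The estimated value for compound 3 is 150000 nM, with an expected range from 40000 nM to 330000 nM.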

Compound 3, half-maximal inhibitory concentration: > 328000 nM
Compound 3: only a limit was reported; the forecaster's own chance of this, stated with the estimate: 55%; middle value at least 2.1-fold (0.33 log units) away from the limit.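

For the compounds shown here, compound 1 and compound 3 are both reported only as limits in this assay, so no step between them can be read. The compounds shown leave open whether butylamino and pyrrolidin-1-yl on that aromatic carbon differ at all in cytotoxicity.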